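This account rests on a few compounds, and the source may have more. Where it says the series, first, only, none or still open, it means among the compounds named here.

Measured so far in this series:
compound 1, `COCCNC(=O)c1cc2cccc(OC)c2oc1=N`, > 70%
compound 2, `COc1cc(Br)cc2cc(C(=O)NCCCO)c(=N)oc12`, 31%
compound 3, `CCC(CO)NC(=O)c1cc2cc(Cl)ccc2oc1=N`, 7%

In an assay on CHO cells for displacement of a labelled ligand from adenosine receptor A1 (Homo sapiens), read by scintillation counting, with a stated time of 60 min, tested at 10 uM (a higher number here means more inhibition at the concentration tested (going by the name of the read-out), a lower number less inhibition), compound 1 gives > 70%, which is a limit of the assay and not a number. Compound 1 therefore stands at the top of the values shown, at the limit of > 70% in this assay, at which 1 of the 3 values shown sits. Among the compounds with values here, compound 2 gives 31% and compound 3 gives 7% in this assay; both differ from compound 1 in more than one place, so no single step to either is given, and their values are taken only as the range the series covers.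

Compound 4, `COc1cccc2cc(C(=O)NCCCCCO)c(=N)oc12`, is not yet measured. It differs from compound 1 as 3-hydroxypropyl in place of methoxy on a saturated chain carbon, two bonds along the chain from an amide-type nitrogen. Within the data shown here, no measured pair isolates this change. A moderate downward step in this assay is expected, since compound 2, which also carries a 3-hydroxypropyl on the amide-type nitrogen, gives 31%, though it is not a clean comparison. For compound 4 the estimate in this assay is 55%, with the expected step of a number at least 15 percentage points lower from compound 1 to compound 4 (beyond the scatter), in the range 25% to 80%.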

Compound 4, a percentage reported as inhibition, at one concentration (the size of the read-out at that concentration, not a potency): 44%
Estimate against measurement, compound 4: 11 percentage points above, within the range that was stated.
By their numbers in this assay, from the lowest: compound 3; then compound 2; then compound 4. At a limit, above all of these: compound 1.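

In this assay, within the data shown here, the change from methoxy to 3-hydroxypropyl on a saturated chain carbon, two bonds along the chain from an amide-type nitrogen, gives the first single-place step: a number at least 26 percentage points lower from compound 1 to compound 4 (beyond the scatter). The value of compound 1 is a limit of the assay and not a number: the limit of > 70% in this assay, at which 1 of the 4 values shown sits. The read-out is therefore sensitive to this change at this position, while the full size of the step stays unfixed.

The compounds shown do not separate the share of the longer chain from that of the hydroxyl at its end. From the compounds shown here alone, how a plain pentyl chain, a shorter 2-hydroxyethyl group or a chain ending in an amine or a carboxylic acid would read at this place remains open.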